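Inverting both stereocentres of compound 2

The source may hold more compounds than are shown below. What is called first, only, known or untested is meant among the compounds shown, and "the series" means these compounds.

In a functional assay on SW480 cells (Homo sapiens) for cytotoxicity, read by MTT assay, with a stated time of 48 h (a higher number here means a weaker inhibitor, a lower number a stronger inhibitor), compound 1 `CCOC(=O)[C@@]1(C(=O)Nc2ccccc2)C[C@@H]1c1cc(OC)c(OC)c(OC)c1` reports only a limit, > 100000 nM. Compound 2 `CCOC(=O)[C@@]1(C(=O)Nc2ccccc2Cl)C[C@@H]1c1cc(OC)c(OC)c(OC)c1` gives 46700 nM and compound 3 `COc1cc([C@H]2C[C@]2(CO)C(=O)NCc2ccc(C)cc2)cc(OC)c1OC` gives 94000 nM, two values within the scatter of each other. The next comparison is compound 4 `CCOC(=O)[C@]1(C(=O)Nc2ccccc2Cl)C[C@H]1c1cc(OC)c(OC)c(OC)c1` against compound 2: the two compounds have the same atoms and bonds and differ only in configuration as drawn: 2 of 2 stereo elements differ (all stereocentres are inverted: mirror images); a stereocentre at a saturated ring carbon is drawn S in compound 2 and R in compound 4; a stereocentre at a saturated ring carbon is drawn R in compound 2 and S in compound 4. Among the measured compounds shown here, the only measured step, an at least 2.1-fold lower number from compound 1 to compound 2 (0.33 log units; beyond the scatter), is chloro in place of hydrogen on an aromatic carbon, and it involves no change of configuration. For the measured compounds named here, no measured pair tests inversion, so the direction stays open, and a 1.3-fold higher number from compound 2 to compound 4 (0.11 log units; within the scatter) is the expected step, not clearly beyond the scatter. Compound 4 is estimated at 60000 nM, with an expected range from 20000 nM to 150000 nM.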

Compound 4, half-maximal inhibitory concentration: 25600 nM
The estimate for compound 4 lay 2.3-fold (0.37 log units) above the measured number; low and high end bracket the measured number.
By their numbers in this assay, from the lowest: compounds 4, 2 and 3 (each within the scatter of the next, the first and the last beyond it). At a limit, above all of these: compound 1.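

In this assay, among the compounds shown here, inverting both stereocentres gives a 1.8-fold lower number from compound 2 to compound 4 (0.26 log units; within the scatter), the first reading on configuration. The pair isolates configuration from any change of substituent: the fact that compounds 2 and 4 differ only in the configuration as drawn. At this level of activity, the mirror-image change therefore shows no effect that can be told from the scatter.

Open, from the compounds shown here alone, is what inverting one stereocentre alone would do, since both change together here. Also open, going by these compounds, is whether the inversion stays this small when an amine or a carboxylic acid replaces the chloro or the ethyl ester.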